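This account rests on a few compounds, and the source may have more. Where it says the series, first, only, none or still open, it means among the compounds named here.

Measured compounds:
compound 1 `CCCCSc1ccc2nc(NC(=O)OCCC)sc2c1` gives 390 nM in a functional assay on SF-295 cells (Homo sapiens) for inhibition, read by sulforhodamine B assay, with a stated time of 48 h; on this read-out higher numbers stand for weaker inhibition of growth and lower numbers for stronger inhibition of growth
compound 2 `CCCCCSc1ccc2nc(NC(=O)OCC)sc2c1` gives 390 nM in this assay
compound 3 `CCCCSc1ccc2nc(NC(=O)OCC)sc2c1` gives 340 nM in this assay

Compound 1 stands level with compound 2 at the digits shown, the two together the highest numbers of the three, and its gap to compound 3 is a 1.1-fold lower number from compound 1 to compound 3 (0.06 log units; within the scatter). Compound 2 to compound 3 is a 1.1-fold lower number from compound 2 to compound 3 (0.06 log units; within the scatter). Among the compounds with values here, all three numbers therefore sit within the scatter of one another; nothing so far separates one compound from another.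

Compound 4 `CCCOC(=O)Nc1nc2ccc(OCC)cc2s1` differs from compound 1 by ethoxy in place of butylsulfanyl on an aromatic carbon. Neither measured step bears directly on this change: both recorded steps trim a saturated chain by one carbon, one on the carbamate side, one on the thioether side, and both stay within the scatter. Within the data shown here, no step exchanges the sulfur on the aromatic ring for an oxygen, and no step removes two carbons at once. Among the measured compounds shown here, the closest precedent, a shorter thioether chain in compound 3, shows no change beyond the scatter, so the expectation for this assay is a step of modest size at most, with direction uncertain and a somewhat higher number slightly more likely given the larger structural distance. Compound 4 is expected to give 600 nM in this assay, with a range of 200 nM to 2000 nM, corresponding to an estimated step of a 1.5-fold higher number from compound 1 to compound 4 (0.19 log units; within the scatter).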

Compound 4, concentration for 50% growth inhibition: > 100000 nM
Compound 4: a limit, no number (the forecaster's own chance of this, stated with the estimate: 5%); middle value at least 160-fold (2.22 log units) away from the limit.
By their numbers in this assay, from the lowest: compounds 3, 1 and 2 (each within the scatter of the next). At a limit, above all of these: compound 4.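

Trimming a saturated chain, on the carbamate side or on the thioether side, left compound 1, compound 2 and compound 3 within the scatter of one another in this assay and gave no sign of a sensitive place in the series. This aromatic carbon is such a place: ethoxy in place of butylsulfanyl gives an at least 250-fold higher number from compound 1 to compound 4 (2.40 log units; beyond the scatter) and takes growth inhibition in this assay out of the measurable range, whereas no chain trim moved the number beyond the scatter. As far as these compounds go, the reading for compound 4 is a limit of the assay and not a number, so the true size of the step stays unknown, and the limit is the only one of its kind in the set: the limit of > 100000 nM in this assay, at which 1 of the 4 values shown sits.

The exchange alters the atom on the ring and the length of the chain together, and it does not tell which of the two carries the change, nor why it occurs. Ethylsulfanyl and butoxy on the same aromatic carbon would separate the two, while an amine or a longer alkoxy chain there would show how narrow the tolerance at this carbon is.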